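The source may hold more compounds than are shown below. What is called first, only, known or untested is meant among the compounds shown, and "the series" means these compounds.

Measured compounds in the series:

- compound 1, `Nc1cccc(CNc2cc(C(F)(F)F)cc3[nH]ncc23)c1`: 24%
- compound 2, `Cc1ccc(CNc2cc(C(F)(F)F)cc3[nH]ncc23)c([N+](=O)O)c1`: 36%

Both numbers come from an assay for inhibition of Indoleamine 2,3-dioxygenase 1 (Homo sapiens), with stated times of 10 min and 60 min, tested at 10 uM; on this read-out lower numbers stand for a weaker effect and higher numbers for a stronger effect at the one concentration tested. Compound 1 stands lowest of the two values shown; its nearest neighbour is compound 2, whose value is higher by a margin beyond the usual scatter. For the measured compounds named here, no step between two measured compounds that differ in one place is available, so the two values show only that compound 2 reads higher than compound 1 in this assay and nothing about any single structural change.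

The next compound to be measured is compound 3, `FC(F)(F)c1cc(NCc2cccc(Br)c2)c2cn[nH]c2c1`. It differs from compound 1 in one place: bromo in place of amino on an aromatic carbon. Nothing measured in this series separates the contribution of the amino group from that of the rest of the molecule, so the direction of the step is open. The working expectation is a step from compound 1 to compound 3 of a number 6 percentage points higher from compound 1 to compound 3 (within the scatter), which is within the scatter of this assay. Compound 3 is therefore estimated at 30%, with a range from 10% to 50%.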

Compound 3, a percentage reported as inhibition, at one concentration (the size of the read-out at that concentration, not a potency): 23%
Estimate against measurement, compound 3: 7 percentage points above; the measured number falls inside the stated range.
By their numbers in this assay, from the lowest: compounds 3 and 1 (each within the scatter of the next); then compound 2.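

Read in this assay, the change from 3-aminophenyl to 3-bromophenyl gives a number 1 percentage points lower from compound 1 to compound 3 (within the scatter) and is the first single-place step in the series. At this position, on an aromatic carbon of a six-membered aromatic ring of carbon only and meta to a large group, the exchange removes the hydrogen-bond donor and acceptor counted for amino, yet the read-out at the one tested concentration does not separate the two compounds. For this pair, then, the amino group is not needed to keep the read-out at this level, and a bromo group serves equally well within the scatter, although no measurement shown addresses why the two compounds read alike.

Going by these compounds, whether a different group here, such as a carboxylic acid, a methoxy group or a nitrile, would move the read-out beyond the scatter remains open, as does whether compounds 1 and 3 would also match in a full concentration series. Compound 2 differs from both in more than one place, so its value cannot be tied to any single change.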